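Triazole thioether series: cytotoxicity limits and compound 4

A few compounds are considered here, and "the series" means these few. Any claim that something is new, unique, unknown or untested is made for them only; others in the source may bear on it.

Compound 1 `Cn1cc(SCc2nnc(SCc3ccccc3OC(F)(F)F)n2-c2c(Cl)cccc2Cl)c2ccccc21`. In a toxicity assay on HEK-293T cells (Homo sapiens) for cytotoxicity, read by CCK-8 assay, with a stated time of 48 h (on this read-out higher numbers stand for lower toxicity in this test and lower numbers for higher toxicity in this test), compound 1 gives only the assay limit > 100000 nM.
Compound 2 `Cn1cc(SCc2nnc(SCc3cc(Cl)ccc3F)n2-c2c(Cl)cccc2Cl)c2ccccc21`. In this assay compound 2 gives only the assay limit > 100000 nM.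
Compound 3 `Cn1cc(SCc2nnc(SCc3ccc(Cl)c(F)c3)n2-c2c(Cl)cccc2Cl)c2ccccc21`. In this assay compound 3 gives only the assay limit > 100000 nM.

Compound 3 therefore stands at the limit, as do all values shown so far (the limit of > 100000 nM in this assay, at which 3 of the 3 values shown sit). Compound 4 `Cn1cc(SCc2nnc(SCc3ccc(OC(F)(F)F)c(Cl)c3)n2-c2c(Cl)cccc2Cl)c2ccccc21` differs by 3-chloro-4-(trifluoromethoxy)phenyl in place of 4-chloro-3-fluorophenyl on a saturated chain carbon bound to a sulfur. The measured steps that bear on this exchange of the aryl group are a step that the two limits leave unreadable from compound 1 to compound 3, a step that the two limits leave unreadable from compound 2 to compound 3 and a step that the two limits leave unreadable from compound 1 to compound 2; none of them is readable, since both ends sit at the limit. No step beyond the scatter is expected in this assay, in either direction. Compound 4 is estimated at 100000 nM, expected between 50000 nM and 200000 nM. The expected step of a number no higher from compound 3 to compound 4 (the limit leaves the size open) is most likely to remain unresolved as a further limit.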

Compound 4, half-maximal cytotoxic concentration: 77700 nM
Compound 4: the middle estimate sits 1.3-fold (0.11 log units) above what was measured, and the stated range covers the measured number.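

With 3-chloro-4-(trifluoromethoxy)phenyl on the saturated chain carbon bound to a sulfur, compound 4 gives the first number in this assay that is not a limit, and the other values remain limits: the limit of > 100000 nM in this assay, at which 3 of the 4 values shown sit.

The exchange reads as an at least 1.2-fold lower number from compound 3 to compound 4 (0.10 log units; that floor lies within the scatter), as an at least 1.2-fold lower number from compound 2 to compound 4 (0.10 log units; that floor lies within the scatter) and as an at least 1.2-fold lower number from compound 1 to compound 4 (0.10 log units; that floor lies within the scatter). These floors do not establish higher toxicity for compound 4, and the steps among compound 1, compound 2 and compound 3 still cannot be read.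

Open, from the compounds shown here alone, is how an amine or a carboxylic acid on this aryl ring, in place of its halogens, would read in this assay.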